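A Piperidine Methyl Carried Into the Fluorophenyl Series

The source may hold more compounds than are shown below. What is called first, only, known or untested is meant among the compounds shown, and "the series" means these compounds.

Measured compounds in a functional assay on MKN-45 cells (Homo sapiens) for inhibition, read by MTT assay, with a stated time of 72 h; on this read-out higher numbers stand for weaker inhibition and lower numbers for stronger inhibition:

Compound 1, `COc1cc2c(Oc3ccc(NC(=O)c4nn(-c5ccccc5C)c(=O)cc4C)cc3F)ccnc2cc1OCCCN1CCCCC1`: 1310 nM
Compound 2, `COc1cc2c(Oc3ccc(NC(=O)c4nn(-c5ccccc5C)c(=O)cc4C)cc3F)ccnc2cc1OCCCN1CCC(C)CC1`: 1290 nM
Compound 3, `COc1cc2c(Oc3ccc(NC(=O)c4nn(-c5cccc(F)c5)c(=O)cc4C)cc3F)ccnc2cc1OCCCN1CCCCC1`: 130 nM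

Three compounds share one scaffold and differ at two places. Between compound 1 and compound 2 the change is methyl in place of hydrogen on a saturated ring carbon, and the step of a 1.0-fold lower number from compound 1 to compound 2 (0.01 log units; within the scatter) shows that the two values cannot be told apart. Between compound 1 and compound 3 the cores differ by 3-fluorophenyl in place of 2-methylphenyl on an aromatic nitrogen, and here the step of a 10-fold lower number from compound 1 to compound 3 (1.00 log units; beyond the scatter) is a clear one, leaving compound 3 with the lowest number of the three.

Compound 4, `COc1cc2c(Oc3ccc(NC(=O)c4nn(-c5cccc(F)c5)c(=O)cc4C)cc3F)ccnc2cc1OCCCN1CCC(C)CC1`, has not yet been measured. It stands to compound 3 as compound 2 stands to compound 1: the change methyl in place of hydrogen on a saturated ring carbon is the same change, made on the core of compound 3 rather than on the core of compound 1. For the measured compounds named here, since the only measured instance of this change, the step of a 1.0-fold lower number from compound 1 to compound 2 (0.01 log units; within the scatter), lay within the scatter, the expectation is that compound 4 will sit close to compound 3, with an expected step of no change at the digits printed from compound 3 to compound 4 (within the scatter). This rests on a single pair, compound 1 and compound 2, so the expectation is held loosely.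

The estimate for compound 4 in this assay is 130 nM, with an expected range from 60 nM to 280 nM.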

Compound 4, half-maximal inhibitory concentration: 140 nM
For compound 4 the middle estimate is 1.1-fold (0.03 log units) below the measured one; the range from low to high includes it.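

In this assay, for the compounds shown here, methyl in place of hydrogen on a saturated ring carbon, which turns piperidin-1-yl into 4-methylpiperidin-1-yl, gives a 1.1-fold higher number from compound 3 to compound 4 (0.03 log units; within the scatter), and this step agrees with the one seen on the other core: the same change on two cores in this assay, a 1.0-fold lower number (0.01 log units; within the scatter) from compound 1 to compound 2 and a 1.1-fold higher number (0.03 log units; within the scatter) from compound 3 to compound 4, 1.1-fold (0.04 log units) apart, within the scatter of two such steps The second change, 3-fluorophenyl in place of 2-methylphenyl on an aromatic nitrogen, also carries over, giving a 9.2-fold lower number from compound 2 to compound 4 (0.96 log units; beyond the scatter) with the 4-methylpiperidin-1-yl group in place, which matches the step seen with piperidin-1-yl: the same change on two cores in this assay, a 10-fold lower number (1.00 log units; beyond the scatter) from compound 1 to compound 3 and a 9.2-fold lower number (0.96 log units; beyond the scatter) from compound 2 to compound 4, 1.1-fold (0.04 log units) apart, within the scatter of two such steps Within these four compounds, then, each change gives the same result whichever form the other place takes, but this rests on only two cores and one assay, and it shows neither why the steps agree nor that they would agree on any other core.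

The compounds shown leave open whether the methyl would remain without effect if a morpholine replaced the piperidine or if a longer chain linked that ring to the shared core. They also leave open whether the step from 2-methylphenyl to 3-fluorophenyl comes from the loss of the methyl or the arrival of the fluorine, a question that an unsubstituted phenyl on the same nitrogen would help to separate.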